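A few compounds are considered here, and "the series" means these few. Any claim that something is new, unique, unknown or untested is made for them only; others in the source may bear on it.

Compound 1 `CCc1ccccc1N(CC(=O)NCc1cccc(Cl)c1)S(=O)(=O)c1ccc(C)cc1` gives 1410 nM in a functional assay on CHO-K1 cells for antagonist activity at prostaglandin E2 receptor EP1 subtype (Homo sapiens), read by FLIPR and calcium flux; on this read-out lower numbers stand for stronger inhibition and higher numbers for weaker inhibition. Compound 2 `CCc1ccccc1N(CC(=O)NCc1ccc(C(F)(F)F)cc1)S(=O)(=O)c1ccc(C)cc1` gives 209 nM in this assay, and a 6.7-fold lower number from compound 1 to compound 2 (0.83 log units; beyond the scatter) comes from putting 4-(trifluoromethyl)phenyl in place of 3-chlorophenyl on the saturated chain carbon bound to the amide-type nitrogen. For compound 3 `Cc1ccc(S(=O)(=O)N(CC(=O)NCc2ccc(Cl)cc2)c2ccccn2)cc1` only a limit is recorded, < 1450 nM; this is the limit of < 1450 nM in this assay, at which 1 of the 3 values shown sits, and compound 3 stands at that limit, not at a number. Compound 4 `Cc1ccc(S(=O)(=O)N(CC(=O)NCc2ccc(Cl)cc2)c2ccc(C)cn2)cc1` differs from compound 3 by methyl in place of hydrogen on an aromatic carbon. Within the data shown here, the single measured step concerns the chain-end aryl, not this ring, so it does not bear on the change. No step beyond the scatter is expected, and a step that the limit leaves unreadable from compound 3 to compound 4 is the estimate. Compound 4 is expected to give 800 nM, within 150 nM to 3500 nM.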

Compound 4, inhibition constant: < 1450 nM
Compound 4: a limit, no number; the forecaster's own chance of this, stated with the estimate: 30%; the middle value lies beyond the limit too.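

No step can be read from compound 3 to compound 4, since each is recorded only as a limit and not as a number: the limit of < 1450 nM in this assay, at which 2 of the 4 values shown sit.

The compounds shown leave open whether 5-methylpyridin-2-yl in place of pyridin-2-yl changes inhibition at all.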